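The compounds below may be only part of what the source reports. "The series", "measured", "known", "first", "only" and "open" are said of these compounds alone.

Compound 1 `O=C(Nc1ccc(F)cc1)N1N=C(c2ccc(Br)cc2)CC1c1ccc(F)cc1` gives in an assay on HEK293 cells for inhibition of Voltage-dependent L-type calcium channel subunit alpha-1C (Homo sapiens), read by FLIPR and calcium flux, with a stated time of 3 min (on this read-out lower numbers stand for stronger inhibition and higher numbers for weaker inhibition), a limit of the assay, > 10000 nM.
Compound 2 `O=C(Nc1ccc(F)cc1)N1N=C(c2ccccc2)CC1c1ccc(F)cc1` gives in this assay a limit, > 10000 nM.
Compound 3 `CC1=NN(C(=O)Nc2ccc(F)cc2)C(c2ccc(F)cc2)C1` gives in this assay a limit, > 10000 nM.

Compound 2 therefore stands only at the limit of > 10000 nM in this assay, at which 3 of the 3 values shown sit, and no number is known for it. Compound 4 `CC1CC(c2ccccc2)=NN1C(=O)Nc1ccc(F)cc1` differs from it in one place: methyl in place of 4-fluorophenyl on a saturated ring carbon. Within the data shown here, two measured steps touch compound 2, a step that the two limits leave unreadable from compound 1 to compound 2 and a step that the two limits leave unreadable from compound 2 to compound 3, and neither gives a readable size or direction, since both ends sit at the limit. Among the measured compounds shown here, no measured step therefore points to a change in this assay beyond the scatter. Compound 4 is expected to remain around 20000 nM, between 5000 nM and 100000 nM. The estimated step is a step that the limit leaves unreadable from compound 2 to compound 4.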

Compound 4, half-maximal inhibitory concentration: 3900 nM
Estimate against measurement, compound 4: 5.1-fold (0.71 log units) above; measured number outside the range, below it.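

In this assay, methyl in place of 4-fluorophenyl on the saturated ring carbon gives an at least 2.5-fold lower number from compound 2 to compound 4 (0.40 log units; beyond the scatter). Among these compounds, the earlier steps cannot be read, so this is the first sign that a change at this position can shift the inhibition, with methyl on the stronger side. Compound 4 alone leaves the shared limit: the limit of > 10000 nM in this assay, at which 3 of the 4 values shown sit.

Going by these compounds, the true size of the step remains open, as compound 2 has no number. Also open, on these data alone, is how an ethyl group, a longer chain or an amine on this carbon would read, and whether the gain comes from methyl itself or from the loss of 4-fluorophenyl.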